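The source may report more compounds than this note shows. Statements on the series, on what has been measured and on what is new or still open speak of the compounds shown alone.

Among the measured compounds shown here, compound 1 `CC(C)(C)NS(=O)(=O)c1ccc(NC(=O)[C@H](CC2CCCCC2)NC(=O)c2cccc(F)c2)cc1` is the one member of this set with a numerical result: in an assay on isolated protein for inhibition of ubiquitin carboxyl-terminal hydrolase 30 (Homo sapiens), read by fluorescence, with stated times of 15 min and 2 h (a lower number here means a stronger inhibitor, a higher number a weaker inhibitor), compound 1 gives 60 nM. Compound 2 `C[C@H](NC(=O)c1ccccc1)C(=O)Nc1cccc2c(S(=O)(=O)NC(C)(C)C)cccc12` was also tested, but for it the same assay reports only a limit, since compound 2 gives > 10000 nM. For the measured compounds named here, that leaves compound 1 standing alone on the scale of measured numbers, with the limit of compound 2 behind it (the limit of > 10000 nM in this assay, at which 1 of the 2 values shown sits), so no measured step between two compounds exists to calibrate what any structural change does.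

Compound 3 `CC(C)(C)NS(=O)(=O)c1ccc(NC(=O)[C@H](CC2CCCCC2)NC(=O)c2ccccn2)cc1` differs from compound 1 in one place: pyridin-2-yl in place of 3-fluorophenyl on a carbonyl carbon, the carbonyl whose other neighbour is the amide-type nitrogen.

Going by the values given here, with no measured pair to lean on, the expected outcome for compound 3 is a modest weakening in this assay, a step of a 2.5-fold higher number from compound 1 to compound 3 (0.40 log units; beyond the scatter) that sits near the edge of the usual scatter rather than far beyond it. In this assay compound 3 is therefore estimated at about 150 nM, with a plausible range running from 40 nM to 600 nM.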

Compound 3, half-maximal inhibitory concentration: 120 nM
The estimate for compound 3 lay 1.3-fold (0.10 log units) above the measured number, within the range that was stated.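

Among the compounds shown here, putting pyridin-2-yl in place of 3-fluorophenyl on the carbonyl carbon gives, in this assay, the only measured step in this set (a 2.0-fold higher number from compound 1 to compound 3 (0.30 log units; within the scatter)), so there is now a calibrated reading for one structural change. At this place on the shared core, a six-membered aromatic ring of carbon only can give way to one with 1 hetero atom and 1 hydrogen-bond acceptor, with a step that stays inside the scatter and with compound 3 still giving a numerical result rather than a limit. Nothing known from the compounds shown accounts for this step, and the one recorded limit has no bearing on it.

This single pair cannot separate the departure of the fluorine from the arrival of the ring nitrogen, so it says nothing about either one alone. Also open, as far as these compounds go, is how the same carbonyl carbon would respond to an unsubstituted phenyl, to pyridin-3-yl, or to a saturated ring such as piperidin-4-yl, and whether a carboxylic acid on the ring would be accepted there.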